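Dropping One Methoxy Group from Compound 3

The source may report more compounds than this note shows. Statements on the series, on what has been measured and on what is new or still open speak of the compounds shown alone.

Among the measured compounds shown here, compound 3, `COc1ccc(-c2nc(O)c3c(n2)c(C)nn3C)cc1OC`, is one of three compounds measured in an assay on membranes from brain for binding affinity to adenosine receptor A1 (Rattus norvegicus), read by radioligand binding; a higher number here means a weaker inhibitor, a lower number a stronger inhibitor. Of those three numbers compound 3 gives the highest, at 1920 nM. Compound 1, `Cc1nn(C)c2c(O)nc(-c3ccccc3)nc12`, which shares the core but lacks both methoxy groups, gives 1020 nM, a number that lies within the scatter of the value of compound 3, so no order between the two can be read. Compound 2, `Cn1c(=O)c2nc(-c3ccc([N+](=O)[O-])cc3)[nH]c2n(C)c1=O`, built on a different core, gives 8 nM, far beyond the scatter from compound 3.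

Compound 4, `COc1cccc(-c2nc(O)c3c(n2)c(C)nn3C)c1`, has not been measured in this assay. It differs from compound 3 by hydrogen in place of methoxy on an aromatic carbon. For the measured compounds named here, no step between two measured compounds matches this change. Going by the values given here, the only guide is that compound 1 and compound 3 sit within the scatter of each other, so the ring without methoxy groups and the ring carrying two of them give similar numbers. The expectation is a step of a 1.5-fold lower number from compound 3 to compound 4 (0.17 log units; within the scatter), no larger than the scatter, leaning slightly toward a lower number. Compound 4 is therefore estimated at 1300 nM, with a range from 450 nM to 3800 nM.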

Compound 4, half-maximal inhibitory concentration: 1470 nM
Estimate against measurement, compound 4: 1.1-fold (0.05 log units) below; low and high end bracket the measured number.
By their numbers in this assay, from the lowest: compound 2; then compounds 1, 4 and 3 (each within the scatter of the next).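

In this assay, hydrogen in place of the methoxy group that stands para to a large group and ortho to a methoxy group gives a 1.3-fold lower number from compound 3 to compound 4 (0.12 log units; within the scatter), so at this position the two substituents cannot be told apart. Compound 1 and compound 3 differ in two places, which left the contribution of each methoxy group unseparated, but the new steps take them one at a time: methoxy in place of hydrogen on the ring of compound 1 gives a 1.4-fold higher number from compound 1 to compound 4 (0.16 log units; within the scatter), and neither single change leaves the scatter. Nothing available here offers an independent measurement that could account for this flat result.

The compounds shown leave open whether a different group at this position, such as an amine, a carboxylic acid or a longer alkoxy chain, would shift the number beyond the scatter. From the compounds shown here alone, compound 2 gives 8 nM on a different core, and whether any group on this ring could bring the shared core to a number of that order also remains open.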